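Cytotoxicity notes on a piperidine carboxamide series

The source may report more compounds than this note shows. Statements on the series, on what has been measured and on what is new or still open speak of the compounds shown alone.

The series shares a core in which a cyclic amide bearing an aromatic acyl group carries an anilide; compound 1 `O=C(Nc1cccc(Oc2ccccc2)c1)C1CCCN(C(=O)c2cccc(-c3ccco3)c2)C1`, compound 2 `COC(=O)c1cccc(C(=O)N2CCCC(C(=O)Nc3ccc(Cl)cc3)C2)c1` and compound 3 `CC(=O)c1cccc(NC(=O)C2CCCN(C(=O)c3cc(C(F)(F)F)cc(C(F)(F)F)c3)C2)c1` have all been run in an ADME assay on PC-3 cells (Homo sapiens) for cytotoxicity, read by WST assay, tested at 100 uM; a higher number here means more inhibition at the concentration tested (going by the name of the read-out), a lower number less inhibition. In this assay compound 1 gives 0%, compound 2 gives 0% and compound 3 gives 0%. Compound 2 thus stands level with compound 1 and with compound 3 at the digits shown, all within the usual scatter, so no ordering among the three can be read from these numbers.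

Compound 4 `CSc1cccc(C(=O)N2CCCC(C(=O)Nc3ccc(Cl)cc3)C2)c1` is not yet measured. It differs from compound 2 in one place: methylsulfanyl in place of methoxycarbonyl on an aromatic carbon. Among the measured compounds shown here, no step between measured compounds is available for this kind of change. Given that compound 1, compound 2 and compound 3 all sit at the same level, no step beyond the scatter is expected; the estimated step is a number 2 percentage points higher from compound 2 to compound 4 (within the scatter). Compound 4 is therefore expected to give about 2% in this assay, in a range from -8% to 15%.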

Compound 4, a percentage reported as inhibition, at one concentration (the size of the read-out at that concentration, not a potency): 0%
For compound 4 the middle estimate is 2 percentage points above the measured one, within the range that was stated.
By their numbers in this assay, from the lowest: compounds 1, 2, 3 and 4 (each within the scatter of the next).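

Among the compounds shown here, the only one-place step available, methylsulfanyl in place of methoxycarbonyl on an aromatic carbon, gives no change at the digits printed from compound 2 to compound 4 (within the scatter) in this assay. At this position, meta to a large group, a substituent with a carbonyl and one without a carbonyl therefore read alike, with the rest of compound 2 held fixed. No supporting data on hand bear on why this is so.

Open, going by these compounds, is whether an amine, a carboxylic acid or a longer alkyl chain on this aromatic carbon would lift the read-out in this assay away from the level shared by compound 2 and compound 4. Also open, on these data alone, is whether the same change would read alike with other acyl or anilide groups on the shared core.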